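The source may report more compounds than this note shows. Statements on the series, on what has been measured and on what is new or still open speak of the compounds shown alone.

Three compounds share one core and differ in the groups attached to it: compound 1 `CCC1C(=O)N(C)c2cnc(-n3ccc4cc(C(=O)NC)ccc43)nc2N1c1ccn(C)n1`, compound 2 `CC[C@@H]1C(=O)N(C)c2cnc(Nc3ccc(S(N)(=O)=O)cc3)nc2N1C1CCCC1` and compound 3 `CCC1C(=O)N(C)c2cnc(Nc3ccc(S(=O)(=O)NCCCO)cc3)nc2N1c1ccn(C)n1`. In a functional assay on NCI-H1975 cells (Homo sapiens) for antiproliferative activity, read by CCK-8 assay, with a stated time of 72 h (on this read-out lower numbers stand for stronger inhibition of growth and higher numbers for weaker inhibition of growth), compound 1 gives 35700 nM, compound 2 gives 5290 nM and compound 3 gives 25800 nM. Compound 3 therefore stands second highest of the three numbers; its nearest neighbour is compound 1, whose number lies within the usual scatter of it, while compound 2 is the furthest, with a lower number that lies beyond the scatter.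

Compound 4 `CCCNS(=O)(=O)c1ccc(Nc2ncc3c(n2)N(c2ccn(C)n2)C(CC)C(=O)N3C)cc1` is not yet measured. It differs from compound 3 by hydrogen in place of hydroxy on a saturated chain carbon, three bonds along the chain from a sulfonamide nitrogen. Among the measured compounds shown here, no pair of measured compounds shows this change, so the record gives no direct guide to its size. Since the change is small and removes only a single heavy atom on a chain, the expected step from compound 3 is a 1.2-fold lower number from compound 3 to compound 4 (0.07 log units; within the scatter), which is expected to lie within the scatter rather than beyond it. For compound 4 in this assay a value of 22000 nM is estimated, with a range from 8000 nM to 60000 nM.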

Compound 4, concentration for 50% growth inhibition: 21700 nM
Estimate against measurement, compound 4: 1.0-fold (0.01 log units) above; the measured number falls inside the stated range.
By their numbers in this assay, from the lowest: compound 2; then compounds 4, 3 and 1 (each within the scatter of the next).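

In this assay, among the compounds shown here, compounds 3 and 4 form the first pair that differs in only one place, and the change gives a 1.2-fold lower number from compound 3 to compound 4 (0.08 log units; within the scatter) within the scatter. Hydrogen can therefore stand in place of hydroxy on this saturated chain carbon, three bonds along the chain from a sulfonamide nitrogen, without a difference that can be told apart in this read-out: 3-hydroxypropyl and propyl give matching numbers on this scaffold. No evidence bearing on this result is available.

From the compounds shown here alone, it remains open whether this position would accept an amine, a carboxylic acid or a longer chain equally well. The compounds shown also leave open whether the match between 3-hydroxypropyl and propyl would hold with other groups on the shared core.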